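Butylsulfanyl for allyloxy at the cytotoxicity limit

The compounds below may be only part of what the source reports. "The series", "measured", "known", "first", "only" and "open" are said of these compounds alone.

Compound 2 `C=CCOc1nc(N)nc2c1ncn2/C=C1/CC1(CO)CO` was examined in an ADME assay on MOLT-3 cells (Homo sapiens) for cytotoxicity, with a stated time of 7 days; a lower number here means that less compound is tolerated, a higher number that more compound is tolerated. In this assay compound 2 reaches only a limit of the assay, > 20000 nM. Compound 1 `CNc1nc(N)nc2c1ncn2/C=C1/CC1(CO)CO` stands at a limit too, > 20000 nM. Compound 3 `Nc1nc(NC2CCCC2)c2ncn(/C=C3/CC3(CO)CO)c2n1` likewise stops at a limit, > 20000 nM. The steps that touch the same place or neighbouring groups, a step that the two limits leave unreadable from compound 1 to compound 2 and a step that the two limits leave unreadable from compound 2 to compound 3, as well as a step that the two limits leave unreadable from compound 1 to compound 3, leave their size unreadable. Compound 4 `CCCCSc1nc(N)nc2c1ncn2/C=C1/CC1(CO)CO` differs from compound 2 in this way: butylsulfanyl in place of allyloxy on an aromatic carbon. With every shown value sitting at the limit of > 20000 nM in this assay, at which 3 of the 3 values shown sit, compound 4 is expected to remain at the limit as well, which means a step that the limit leaves unreadable from compound 2 to compound 4. Compound 4 is therefore estimated at 30000 nM, with a range from 15000 nM to 100000 nM.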

Compound 4, half-maximal cytotoxic concentration: > 20000 nM
Compound 4 gave a limit, no number (the forecaster's own chance of this, stated with the estimate: 85%); the middle value does not contradict the limit.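

In this assay, for the compounds shown here, compound 4 gives only a limit, > 20000 nM, so no step linking it to compound 1, compound 2 or compound 3 can be read. The compounds shown leave open whether any group on this aromatic carbon changes the cytotoxic concentration.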